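Chloro to methyl on the pendant phenyl of compound 2

This account rests on a few compounds, and the source may have more. Where it says the series, first, only, none or still open, it means among the compounds named here.

For the measured compounds named here, compound 2 `CS(=O)(=O)c1ccc(-c2cnc3[nH]cc(-c4nnc(-c5ccc(Cl)cc5)o4)c(=O)c3c2)cc1` gives 11.6% in a functional assay on HepG2 cells (Homo sapiens) for inhibition, read by MTT assay, with a stated time of 24 h, tested at 10 uM (on this read-out lower numbers stand for less inhibition of growth and higher numbers for more inhibition of growth at the one concentration tested), the higher of the two numbers so far, with compound 1 `CS(=O)(=O)c1ccc(-c2cnc3[nH]cc(-c4nnc(-c5ccccc5)o4)c(=O)c3c2)cc1` at 6.98% lying a number 4.6 percentage points higher from compound 1 to compound 2 (within the scatter). Compound 3 `Cc1ccc(-c2nnc(-c3c[nH]c4ncc(-c5ccc(S(C)(=O)=O)cc5)cc4c3=O)o2)cc1` differs from compound 2 by methyl in place of chloro on an aromatic carbon. Going by the values given here, no measured step covers a methyl; the only nearby step, chloro for hydrogen at the same aromatic carbon, stayed within the scatter. Compound 3 is therefore expected to show a number 1.6 percentage points lower from compound 2 to compound 3 (within the scatter), no step beyond the scatter. Compound 3 is estimated at 10%, with a range of 0% to 22%.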

Compound 3, percent growth inhibition at one concentration: 8.94%
For compound 3 the middle estimate is 1.1 percentage points above the measured one, within the range that was stated.
By their numbers in this assay, from the lowest: compounds 1, 3 and 2 (each within the scatter of the next).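

With 4-chlorophenyl to 4-methylphenyl, this assay gives a number 2.7 percentage points lower from compound 2 to compound 3 (within the scatter), and methyl in place of hydrogen on the same aromatic carbon gives a number 2 percentage points higher from compound 1 to compound 3 (within the scatter). Hydrogen, chloro and methyl at this position now all lie within the scatter of one another, so the position has not yet separated any of the three. Nothing available offers an explanation for these numbers. From the compounds shown here alone, whether an amine, a carboxylic acid or a longer chain at this carbon would give a step beyond the scatter stays open.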